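Methoxy in place of fluoro: expecting compound 3

The source may report more compounds than this note shows. Statements on the series, on what has been measured and on what is new or still open speak of the compounds shown alone.

Compound 1 `O=C(/C=C/c1ccccc1Cl)c1ccc(OCc2ccccc2)cc1`: 7100 nM
Compound 2 `O=C(/C=C/c1ccc(F)cc1)c1ccc(OCc2ccccc2)cc1`: > 50000 nM

In a functional assay on CAL-51 cells (Homo sapiens) for inhibition, read by sulforhodamine B assay, with a stated time of 3 days (on this read-out lower numbers stand for stronger inhibition of growth and higher numbers for weaker inhibition of growth), compound 2 gives only a limit, > 50000 nM, and not a number. Compound 3 `COc1ccc(/C=C/C(=O)c2ccc(OCc3ccccc3)cc2)cc1` carries methoxy in place of fluoro on an aromatic carbon. For the measured compounds named here, one measured step bears on this change, and it also involves the 4-fluorophenyl group: an at least 7.0-fold higher number from compound 1 to compound 2 (0.84 log units; beyond the scatter). It shows that a change in that group can move the number beyond the scatter, but it gives no direction for methoxy. A modest step towards a lower number is expected, though a second limit remains possible. The expected step is an at least 2.0-fold lower number from compound 2 to compound 3 (0.30 log units; that floor lies within the scatter). For compound 3 the estimated value is 25000 nM, with an expected range from 7000 nM to 50000 nM.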

Compound 3, concentration for 50% growth inhibition: > 50000 nM
Compound 3 ended at the assay's limit; the forecaster's own chance of this, stated with the estimate: 45%; middle value at least 2.0-fold (0.30 log units) away from the limit.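

In this assay compound 3 gives only a limit, not a number, so the step from fluoro to methoxy cannot be read. Replacing 2-chlorophenyl with 4-methoxyphenyl gives an at least 7.0-fold higher number from compound 1 to compound 3 (0.84 log units; beyond the scatter), which shows that a second group at this place, methoxy as well as fluoro, stays far from the value of compound 1. Compound 2 and compound 3 now share one limit: the limit of > 50000 nM in this assay, at which 2 of the 3 values shown sit.

On these data alone, whether any group on this aromatic carbon can bring the number back within range stays open, for example an amine or a carboxylic acid. As far as these compounds go, it is also open whether compound 1 owes its value to chlorine itself or to where chlorine sits, since compound 1 differs from the other two in both.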